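Thiophen-2-yl for ethyl on the shared core

A few compounds are considered here, and "the series" means these few. Any claim that something is new, unique, unknown or untested is made for them only; others in the source may bear on it.

Compound 2 `CCc1nc(Cl)ncc1C(=O)Nc1cc(C(F)(F)F)cc(C(F)(F)F)c1` gives 400 nM in an assay on Jurkat cells for activation of nuclear factor NF-kappa-B complex (Homo sapiens) (a higher number here means a weaker inhibitor, a lower number a stronger inhibitor), the lowest of the two numbers shown, with compound 1 `O=C(Nc1cc(C(F)(F)F)cc(C(F)(F)F)c1)c1cnc(Cl)nc1C(F)(F)C(F)(F)F` nearest at 800 nM. Compound 3 `Cc1nc(C(F)(F)F)ncc1C(=O)Nc1cc(C(F)(F)F)cc(C(F)(F)F)c1` reaches only the limit > 10000 nM in this assay (the limit of > 10000 nM in this assay, at which 1 of the 3 values shown sits). Within the data shown here, the single measured step at the position of interest, a 2.0-fold lower number from compound 1 to compound 2 (0.30 log units; within the scatter), stays within the scatter, so exchanging the group on that aromatic carbon between a fluorinated and a plain chain moved little.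

Compound 4 `O=C(Nc1cc(C(F)(F)F)cc(C(F)(F)F)c1)c1cnc(Cl)nc1-c1cccs1` differs from compound 2 by thiophen-2-yl in place of ethyl on an aromatic carbon. Among the measured compounds shown here, no measured step covers an aromatic ring at this position; the only guide is the small step from compound 1 to compound 2, which bears on the same carbon but not on a ring. On that basis no shift beyond the scatter is expected, while the uncertainty is wide. Compound 4 is therefore estimated at 600 nM, within a range from 150 nM to 3000 nM. The expected step is a 1.5-fold higher number from compound 2 to compound 4 (0.18 log units; within the scatter).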

Compound 4, half-maximal inhibitory concentration: 9800 nM
Compound 4: middle estimate off by 16-fold (1.21 log units), on the low side; measured number outside the range, above it.
By their numbers in this assay, from the lowest: compounds 2 and 1 (each within the scatter of the next); then compound 4. At a limit, above all of these: compound 3.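

Thiophen-2-yl on this aromatic carbon, next to the ring nitrogen, is not a neutral exchange in this assay: the changes are a 25-fold higher number from compound 2 to compound 4 (1.39 log units; beyond the scatter) and a 12-fold higher number from compound 1 to compound 4 (1.09 log units; beyond the scatter), whereas the change between the two open chains was only a 2.0-fold lower number from compound 1 to compound 2 (0.30 log units; within the scatter). The position therefore distinguishes between groups: ethyl and 1,1,2,2,2-pentafluoroethyl give values within the scatter of each other, while the single aromatic ring shown here gives a much higher number. Nothing in the data shown accounts for this loss.

As far as these compounds go, it remains open whether the loss belongs to aromatic rings at this carbon in general or to thiophen-2-yl alone, which a phenyl ring or a cyclopropyl group here would help to separate. From the compounds shown here alone, how a longer chain such as butyl or an amine would behave at this carbon also remains open.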